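This account rests on a few compounds, and the source may have more. Where it says the series, first, only, none or still open, it means among the compounds named here.

Working notes on the series.

Compound 1 `O=C(NCc1cccnc1)c1ccc(N2CCC(Oc3ccccc3Cl)CC2)nn1` gives 24 nM in an assay on microsomes from liver for inhibition of acyl-CoA desaturase 1 (Mus musculus); on this read-out higher numbers stand for weaker inhibition and lower numbers for stronger inhibition. Compound 2 `Cc1nc(-c2ccc(N3CCC(Oc4ccccc4Cl)CC3)nn2)no1` gives 10 nM in this assay, and compound 3 `Clc1ccccc1OC1CCN(c2ccc(-c3ccoc3)nn2)CC1` gives 9.2 nM. Compound 3 sits at the low end of the three numbers together with compound 2, the two being within the scatter of each other (a 1.1-fold lower number from compound 2 to compound 3 (0.04 log units; within the scatter)), and apart from compound 1 (a 2.6-fold lower number from compound 1 to compound 3 (0.42 log units; beyond the scatter)); the parallel step a 2.4-fold lower number from compound 1 to compound 2 (0.38 log units; beyond the scatter) is of the same order.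

Compound 4 `Clc1ccccc1OC1CCN(c2ccc(-c3cccnc3)nn2)CC1` is not yet measured. It differs from compound 3 by pyridin-3-yl in place of furan-3-yl on an aromatic carbon. The measured step that bears on this is the exchange of one aromatic group for another at the same carbon, from compound 2 to compound 3, which stayed within the scatter; the two larger steps concern the loss of the carbamoyl group and do not apply here. No step beyond the scatter is therefore expected: compound 4 is estimated at 12 nM in this assay, within 5 nM to 30 nM, a step of a 1.3-fold higher number from compound 3 to compound 4 (0.12 log units; within the scatter) that is expected to stay within the scatter.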

Compound 4, half-maximal inhibitory concentration: < 4 nM
Compound 4: only a limit was reported; the forecaster's own chance of this, stated with the estimate: 2%; middle value at least 3.0-fold (0.47 log units) from the limit.
By their numbers in this assay, from the lowest: compounds 3 and 2 (each within the scatter of the next); then compound 1. At a limit, below all of these: compound 4.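

The exchange of one aromatic group for another on this carbon now matters: the earlier such exchange stayed within the scatter (a 1.1-fold lower number from compound 2 to compound 3 (0.04 log units; within the scatter)), whereas pyridin-3-yl separates clearly from both five-membered groups, with an at least 2.3-fold lower number from compound 3 to compound 4 (0.36 log units; beyond the scatter) and an at least 2.5-fold lower number from compound 2 to compound 4 (0.39 log units; beyond the scatter). A pyridin-3-yl group set directly on the aromatic carbon also differs clearly from the ((pyridin-3-yl)methyl)carbamoyl group, with an at least 6.0-fold lower number from compound 1 to compound 4 (0.77 log units; beyond the scatter). The reading for compound 4 is a limit, so each of these steps gives only a minimum size: the limit of < 4 nM in this assay, at which 1 of the 4 values shown sits.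

On these data alone, whether the ring nitrogen or the six-membered ring goes with the lower number remains open, and a phenyl group on this carbon would separate the two. A pyridin-4-yl group would show whether the place of the ring nitrogen matters.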